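From furan-2-yl to furan-3-yl: compound 3 and compound 4

This account rests on a few compounds, and the source may have more. Where it says the series, first, only, none or still open, it means among the compounds named here.

Compound 1 (`COc1ccc(/C=C\c2ccc3ccccc3c2)cc1[N+](=O)[O-]`): > 20000 nM (a limit)
Compound 2 (`C(=C/c1ccco1)\c1ccc2ccccc2c1`): > 5000 nM (a limit)
Compound 3 (`C(=C\c1ccco1)\c1ccc2ccccc2c1`): > 5000 nM (a limit)

In a functional assay on P388 cells (Mus musculus) for inhibition (a higher number here means a weaker inhibitor, a lower number a stronger inhibitor), compound 3 stands at > 5000 nM, which is a limit and not a number. The values of compound 1 and compound 2 are limits too.

Compound 4 (`C(=C\c1ccc2ccccc2c1)\c1ccoc1`) differs from compound 3 by furan-3-yl in place of furan-2-yl on a double-bonded chain carbon bound to a double-bonded chain carbon.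

Among the compounds with values here, the one measured step is a step that the two limits leave unreadable from compound 2 to compound 3 and it concerns (the fact that compounds 2 and 3 differ only in the configuration as drawn), not the furan attachment. No step beyond the scatter, and no direction, is therefore expected in this assay. a step that the limit leaves unreadable from compound 3 to compound 4 is the step expected here. For compound 4 the estimated value is 8000 nM, with an expected range from 3000 nM to 30000 nM and a limit rather than a number again likely.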

Compound 4, half-maximal inhibitory concentration: > 5000 nM
Compound 4 ended at the assay's limit; the forecaster's own chance of this, stated with the estimate: 80%; the middle value does not contradict the limit.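

In this assay compound 4 gives > 5000 nM, which is a limit and not a number. Compound 3 also stands at a limit, and no step can be read between compound 3 and compound 4. The compounds shown leave open whether furan-3-yl or furan-2-yl gives the stronger inhibitor.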